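Removing a Phenyl from a Weak Sulfonamide Inhibitor

The source may report more compounds than this note shows. Statements on the series, on what has been measured and on what is new or still open speak of the compounds shown alone.

Measured compounds:
compound 1, `CC(C)c1cccc(C(C)C)c1OC(=O)NS(=O)(=O)N1CCc2ccccc21`, 43000 nM
compound 2, `CC(C)c1cccc(C(C)C)c1OC(=O)NS(=O)(=O)N(c1ccccc1)c1ccccc1`, 58000 nM

Of the compounds shown here, two have been measured in an assay on liver for inhibition of sterol O-acyltransferase 1 (Rattus norvegicus), using microsomes; a lower number here means a stronger inhibitor, a higher number a weaker inhibitor. Compound 1, built as `CC(C)c1cccc(C(C)C)c1OC(=O)NS(=O)(=O)N1CCc2ccccc21`, gives 43000 nM, and compound 2, built as `CC(C)c1cccc(C(C)C)c1OC(=O)NS(=O)(=O)N(c1ccccc1)c1ccccc1`, gives 58000 nM. Compound 2 shows the higher of the two numbers, but the gap to compound 1 lies within the usual scatter of this assay, so the two compounds cannot be told apart.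

Compound 3, `CC(C)c1cccc(C(C)C)c1OC(=O)NS(=O)(=O)Nc1ccccc1`, differs from compound 2 in one place: hydrogen in place of phenyl on a sulfonamide nitrogen. Going by the values given here, no measured pair shows what such a change does here, so no step size is known. Both measured compounds are weak, and with nothing to point the other way the expected step of a 1.3-fold lower number from compound 2 to compound 3 (0.11 log units; within the scatter) is none beyond the scatter. Compound 3 is therefore estimated at 45000 nM in this assay, with a range from 12000 nM to 160000 nM.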

Compound 3, half-maximal inhibitory concentration: 38100 nM
For compound 3 the middle estimate is 1.2-fold (0.07 log units) above the measured one; measured number inside the range.
By their numbers in this assay, from the lowest: compounds 3, 1 and 2 (each within the scatter of the next).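

In this assay, replacing the phenyl on the sulfonamide nitrogen with hydrogen gives a 1.5-fold lower number from compound 2 to compound 3 (0.18 log units; within the scatter), so removing this whole aromatic ring produces no change that can be separated from the scatter. Putting anilino in place of 2,3-dihydro-1H-indol-1-yl on the sulfonyl sulfur gives a 1.1-fold lower number from compound 1 to compound 3 (0.05 log units; within the scatter), so compound 3 cannot be told apart from compound 1 either, and these changes leave all three compounds indistinguishable. Nothing available explains why these changes make so little difference.

On these data alone, it remains open whether any group on this nitrogen can produce a step beyond the scatter. A methyl group or a longer alkyl chain there, or a carboxylic acid or an amine on the remaining phenyl, could still behave differently.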